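The compounds below may be only part of what the source reports. "The series", "measured", "known", "first", "only" and "open" are said of these compounds alone.

Measured in a functional assay on BGC-823 cells (Homo sapiens) for antiproliferative activity, read by sulforhodamine B assay, tested at 100 ug/mL; on this read-out higher numbers stand for more inhibition at the one concentration tested (going by the name of the read-out) and lower numbers for less inhibition:
compound 1 `Cc1ccc(NS(=O)(=O)C2CCCCC2=O)c(C)c1` gives 15.6%
compound 2 `O=C1CCCCC1S(=O)(=O)Nc1cc(C(F)(F)F)ccc1C(F)(F)F` gives 57.7%
compound 3 `O=C1CCCCC1S(=O)(=O)N1CCOCC1` gives 21.3%

On these numbers compound 1 has the lowest value of the three. Its nearest neighbour is compound 3, whose inhibition lies within the usual scatter of that of compound 1, so no order can be read between the two. Compound 2 lies beyond the scatter and clearly higher.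

Compound 4 `Cc1cc(F)ccc1NS(=O)(=O)C1CCCCC1=O` is the next member. It differs from compound 1 by fluoro in place of methyl on an aromatic carbon. For the measured compounds named here, no pair of measured compounds differs in one place, so no measured step guides this change. In this assay a step of no size beyond the scatter is expected, in either direction. The expected step of a number 2.4 percentage points higher from compound 1 to compound 4 (within the scatter) reflects this. Compound 4 is estimated at 18%, between 5% and 35%.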

Compound 4, a percentage reported as inhibition, at one concentration (the size of the read-out at that concentration, not a potency): 28.7%
Beside the measured number, compound 4's estimate is 10.7 percentage points below it; the range from low to high includes it.
By their numbers in this assay, from the lowest: compounds 1, 3 and 4 (each within the scatter of the next, the first and the last beyond it); then compound 2.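

In this assay, for the compounds shown here, the step of a number 13.1 percentage points higher from compound 1 to compound 4 (beyond the scatter) is the first one read from a change in a single place: fluoro in place of methyl on an aromatic carbon, para to a large group and meta to a methyl group. This position therefore responds to the change, and the direction is upward, though the step is only modest. Nothing measured on these compounds accounts for the step.

From the compounds shown here alone, what chloro, methoxy or an amine would give on this aromatic carbon stays open. So does whether fluoro gives a similar step when the remaining methyl group is replaced.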